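The source may report more compounds than this note shows. Statements on the series, on what has been measured and on what is new or still open speak of the compounds shown alone.

Compound 1 `COC(=O)c1ccc(NCC2Cc3c(N)nc(N)nc3NC2=O)cc1`: in a functional assay on CCRF-CEM cells (Homo sapiens) for inhibition (a higher number here means a weaker inhibitor, a lower number a stronger inhibitor), compound 1 gives > 20 ug/mL, a limit of the assay.
Compound 2 `COC(=O)c1ccc(CCC2Cc3c(N)nc(N)nc3NC2=O)cc1`: in this assay compound 2 gives > 20 ug/mL, again a limit of the assay.

Both readings sit at the limit of > 20 ug/mL in this assay, at which 2 of the 2 values shown sit, so compound 2 stands at a limit rather than a number, and compound 1 shows nothing further. Compound 3 `Nc1nc(N)c2c(n1)NC(=O)C(CCc1ccc(C(=O)O)cc1)C2` differs from compound 2 by hydrogen in place of methyl on an oxygen next to a carbonyl group. Going by the values given here, no step between measured compounds exists, so no size of change can be read from the data; the step from compound 2 to compound 3 is estimated as a step that the limit leaves unreadable from compound 2 to compound 3, with no direction expected beyond the scatter. Compound 3 is expected at 30 ug/mL, between 10 ug/mL and 100 ug/mL, most likely once more only a limit.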

Compound 3, half-maximal inhibitory concentration: 6.7 ug/mL
Estimate against measurement, compound 3: 4.5-fold (0.65 log units) above; the whole stated range lies above it.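

In this assay, the change from methoxycarbonyl to carboxy, hydrogen in place of methyl on an oxygen next to a carbonyl group, brings an at least 2.9-fold lower number from compound 2 to compound 3 (0.47 log units; beyond the scatter). Going by these compounds alone, this single change therefore moves the reading off the limit to a number, which the earlier compounds could not show. The true size of the step stays unknown, since its starting value is a limit and not a number: the limit of > 20 ug/mL in this assay, at which 2 of the 3 values shown sit.

From the compounds shown here alone, whether a carboxamide in place of the carboxy would keep this reading stays open. So does whether carboxy would bring a similar step on the amine-bearing chain of compound 1.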